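Isopropyl in Place of (Methylsulfanyl)methyl: Expecting Compound 4

The source may report more compounds than this note shows. Statements on the series, on what has been measured and on what is new or still open speak of the compounds shown alone.

Compound 1, `COc1ccc(CNC(CCSC)CNC(=O)Nc2c(C(C)C)cccc2C(C)C)cc1`, gives 490 nM.
Compound 2, `COc1ccc(C(=O)NC(CNC(=O)Nc2c(C(C)C)cccc2C(C)C)C2CCCCC2)cc1`, gives 250 nM.
Compound 3, `CCCCCCC(=O)NC(COC(=O)Nc1c(C(C)C)cccc1C(C)C)c1ccccc1`, gives 570 nM; 5100 nM (2 entries).

All three compounds were tested in an assay on isolated protein for inhibition of sterol O-acyltransferase 1 (Rattus norvegicus); on this read-out higher numbers stand for weaker inhibition and lower numbers for stronger inhibition. Compound 1 and compound 2 fall within the usual scatter of each other, so neither can be called the stronger inhibitor on these numbers. Compound 3 was measured twice, and its two entries disagree widely (the several entries of compound 3 in this assay, 570 nM; 5100 nM (2 entries)), which gives a sense of how much single measurements of this kind can move.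

Compound 4, `COc1ccc(CNC(CNC(=O)Nc2c(C(C)C)cccc2C(C)C)CC(C)C)cc1`, has not yet been measured in this assay. It differs from compound 1 in one spot: isopropyl in place of (methylsulfanyl)methyl on a saturated chain carbon, two bonds along the chain from an amine nitrogen. The chain keeps its length and its branching at the same carbon; a sulfur-containing group is traded for an all-carbon one of the same size.

No measured pair among these compounds shows such a swap, so there is no measured step to lean on. The expectation for the step from compound 1 to compound 4 is a change no larger than the scatter, in either direction, giving a 1.2-fold lower number from compound 1 to compound 4 (0.09 log units; within the scatter). Compound 4 is therefore expected to show about 400 nM in this assay, with a likely range from 150 nM to 1300 nM.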

Compound 4, half-maximal inhibitory concentration: 50 nM
Estimate against measurement, compound 4: 8.0-fold (0.90 log units) above; measured number outside the range, below it.
By their numbers in this assay, from the lowest: compound 4; then compounds 2 and 1 (each within the scatter of the next).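

In this assay, putting isopropyl in place of (methylsulfanyl)methyl on a saturated chain carbon, two bonds along the chain from an amine nitrogen, gives a 9.8-fold lower number from compound 1 to compound 4 (0.99 log units; beyond the scatter). This shows that the position is sensitive to which group it carries, even though the group that leaves and the group that enters have the same number of heavy atoms, and that neither sulfur nor the hydrogen-bond acceptor counted on the leaving group is required for inhibition, since the all-carbon compound 4 gives 50 nM. The step rests on a single entry for each compound, and entries in this assay can disagree widely: the several entries of compound 3 in this assay, 570 nM; 5100 nM (2 entries)

This one swap replaces the sulfur and changes the shape of the group at the same time, so the compounds shown cannot separate the two. On these data alone, how a straight propyl chain, a methoxymethyl group with oxygen where the sulfur stood, or a chain ending in an amine or a carboxylic acid would behave at this position remains open, as does whether the step holds up on repeat measurement.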